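Acid to amide on a shared aminothiophene core

The source may hold more compounds than are shown below. What is called first, only, known or untested is meant among the compounds shown, and "the series" means these compounds.

Measured compounds:
compound 1, `Nc1sc2c(c1C(=O)O)CCN(Cc1ccccc1)C2`, 8000 nM
compound 2, `CN1CCc2c(sc(N)c2C(=O)NCc2cccc(Cl)c2)C1`, 13200 nM

Of the compounds shown here, two built on the same aminothiophene core have been tested in an in vitro assay on CHOk1 cells with adenosine receptor A1 (Homo sapiens) as the target; on this read-out lower numbers stand for an effect already at smaller amounts and higher numbers for an effect only at larger amounts of compound. Compound 1 gives 8000 nM, and compound 2 gives 13200 nM; the gap between them lies within the usual scatter of repeated measurements, so the two stand together at the weak end of what is usually sought. Compound 2 also differs from compound 1 in more than one place, so no single-change comparison is available.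

The compound still to be measured is compound 3, `NC(=O)c1c(N)sc2c1CCN(Cc1ccccc1)C2`. Its change from compound 1 is amino in place of hydroxy on a carbonyl carbon. Among the compounds with values here, with no measured pair showing such a change, the step to expect in this assay is uncertain, and it is estimated here to be small, at most a modest move towards lower numbers, as a 1.6-fold lower number from compound 1 to compound 3 (0.20 log units; within the scatter). Compound 3 is therefore expected to give about 5000 nM, within a range from 1500 nM to 20000 nM.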

Compound 3, half-maximal effective concentration: > 20000 nM
Compound 3: a limit, no number; the forecaster's own chance of this, stated with the estimate: 20%; middle value at least 4.0-fold (0.60 log units) from the limit.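

In this assay compound 3 gives > 20000 nM, which is a limit of the assay and not a number. Carboxy to carbamoyl, with amino in place of hydroxy on a carbonyl carbon, is the first change in a single place in this set, and it gives an at least 2.5-fold higher number from compound 1 to compound 3 (0.39 log units; beyond the scatter), so at this position the carboxy group cannot be exchanged for carbamoyl without a loss on this read-out, even though only one heavy atom differs and the count of hydrogen-bond donors and acceptors stays the same. The step can be stated only as a minimum, because the value of compound 3 sits at the end of the range that can be read: the limit of > 20000 nM in this assay, at which 1 of the 3 values shown sits.

The compounds shown do not tell whether a methyl ester, a nitrile or a tetrazole in place of the carboxy group would stay close to compound 1 or fall away as compound 3 does. They also leave open whether the same exchange would cost as much on a core carrying a group other than the benzyl of compound 1, such as a methyl or a longer chain.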